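A few compounds are considered here, and "the series" means these few. Any claim that something is new, unique, unknown or untested is made for them only; others in the source may bear on it.

In an ADME assay on cells (Hepatocyte, Homo sapiens) for metabolic stability, with a stated time of 30 min (a higher number here means that more of the compound is left, a lower number that less of the compound is left), compound 1 `CS(=O)(=O)NC1CCC(CN2CCN(c3cc(=O)c4cc(C(F)(F)F)cc([N+](=O)[O-])c4s3)CC2)CC1` gives 105%, compound 2 `O=C(OC1CCC(CN2CCN(c3cc(=O)c4cc(C(F)(F)F)cc([N+](=O)[O-])c4s3)CC2)CC1)c1ccncc1` gives 1%, and compound 3 `Cc1ccc(C(=O)OC2CCC(CN3CCN(c4cc(=O)c5cc(C(F)(F)F)cc([N+](=O)[O-])c5s4)CC3)CC2)cc1` gives 9.7%. Compound 3 thus lies within the scatter of compound 2 and far under compound 1. Compound 4 `O=C(OC1CCC(CN2CCN(c3cc(=O)c4cc(C(F)(F)F)cc([N+](=O)[O-])c4s3)CC2)CC1)c1ccco1` carries furan-2-yl in place of 4-methylphenyl on a carbonyl carbon. The large steps that replace methanesulfonamido, a number 104 percentage points lower from compound 1 to compound 2 (beyond the scatter) and a number 95.3 percentage points lower from compound 1 to compound 3 (beyond the scatter), concern a different exchange. Among the compounds with values here, the closer guide is the one measured change on a carbonyl carbon, a number 8.7 percentage points higher from compound 2 to compound 3 (within the scatter), so no step beyond the scatter is expected. The expected step is a number 4.7 percentage points lower from compound 3 to compound 4 (within the scatter). For compound 4 the estimated value is 5%, with an expected range of 0.5% to 18%.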

Compound 4, percent of the compound remaining: 1%
The estimate for compound 4 lay 4 percentage points above the measured number, and the stated range covers the measured number.
By their numbers in this assay, from the lowest: compounds 2, 4 and 3 (each within the scatter of the next); then compound 1.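

In this assay, furan-2-yl on the carbonyl carbon gives a result within the scatter of both six-membered aromatic groups (a number 8.7 percentage points lower from compound 3 to compound 4 (within the scatter); no change at the digits printed from compound 2 to compound 4 (within the scatter)). A five-membered aromatic ring with one hetero atom thus leaves the large gap to the methanesulfonamido compound in place (a number 104 percentage points lower from compound 1 to compound 4 (beyond the scatter)). No evidence here bears on the reason for this result. The compounds shown leave open whether a methyl group or an amine on that carbonyl carbon would give a number closer to that of compound 1.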